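Compound 3 Measured Against a Limit

The source may report more compounds than this note shows. Statements on the series, on what has been measured and on what is new or still open speak of the compounds shown alone.

Compound 1 `CC1=C(CC/C(C)=C/CC/C(C)=C/C[C@@H](O)C2=CC(=O)OC2)C(C)(C)C(=O)CC1`: > 10000 nM (a limit)
Compound 2 `CC(=O)O[C@H](C/C=C(\C)CC/C=C(\C)CCC1=C(C)CCC(=O)C1(C)C)C1=CC(=O)OC1`: > 10000 nM (a limit)

In a functional assay on MDA-MB-231 cells (Homo sapiens) for antiproliferative activity, read by sulforhodamine B assay, with a stated time of 48 h (a higher number here means a weaker inhibitor, a lower number a stronger inhibitor), compound 1 gives > 10000 nM, which is a limit and not a number. Compound 2 gives > 10000 nM, which is also a limit. Going by the values given here, compound 1 therefore has no exact position on the scale, and the only measured step, a step that the two limits leave unreadable from compound 1 to compound 2, has no readable size.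

Compound 3 `CC1=C(CC/C(C)=C/CC/C(C)=C/CCC2=CC(=O)OC2O)C(C)(C)C(=O)CC1` has not yet been measured. It has the same atoms as compound 1, joined differently: a group of 8 heavy atoms (5 carbon, 3 oxygen; one five-membered non-aromatic ring with 1 hetero atom) in place of a group of 8 heavy atoms (5 carbon, 3 oxygen; one five-membered non-aromatic ring with 1 hetero atom), on a saturated chain carbon bound to a double-bonded chain carbon. The acetyl change in compound 2 is a different change, so it provides no size to carry over to compound 3.

For compound 3 no step beyond the usual scatter is expected in this assay, because of the limit of > 10000 nM in this assay, at which 2 of the 2 values shown sit. If a number can be read at all, it is expected to lie on the stronger side of that limit. The expected change is a step that the limit leaves unreadable from compound 1 to compound 3. For compound 3 the estimated value is 12000 nM, with an expected range from 4000 nM to 40000 nM.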

Compound 3, half-maximal inhibitory concentration: > 10000 nM
Compound 3: a limit, no number; the forecaster's own chance of this, stated with the estimate: 60%; the middle value does not contradict the limit.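

In this assay, going by these compounds alone, compound 3 gives > 10000 nM, which is a limit and not a number, and compound 1 also stands at a limit, so no step from compound 1 to compound 3 can be read. The compounds shown leave open whether either arrangement of the group carries any measurable antiproliferative activity in this assay.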